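Swapping 3-fluorophenyl for 4-chlorophenyl on the shared core

This account rests on a few compounds, and the source may have more. Where it says the series, first, only, none or still open, it means among the compounds named here.

In a functional assay on HT-29 cells (Homo sapiens) for antiproliferative activity, read by sulforhodamine B assay, with a stated time of 48 h (a higher number here means a weaker inhibitor, a lower number a stronger inhibitor), compound 3 `CCCN1CCN(c2ccc(S(=O)(=O)Oc3cccc(F)c3)cc2)C1=O` gives 18000 nM and compound 2 `CCCN1CCN(c2ccc(S(=O)(=O)Oc3cc(Cl)c(Cl)cc3Cl)cc2)C1=O` gives 19000 nM, so the two stand level within the scatter. Compound 1 `CCCN1CCN(c2ccc(S(=O)(=O)Oc3ccccc3C)cc2)C1=O` reaches only a limit, > 100000 nM.

Compound 4 `CCCN1CCN(c2ccc(S(=O)(=O)Oc3ccc(Cl)cc3)cc2)C1=O` carries 4-chlorophenyl in place of 3-fluorophenyl on an oxygen.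

Among the measured compounds shown here, three measured steps bear on this change. Two of them start from the limit and replace 2-methylphenyl: an at least 5.2-fold lower number from compound 1 to compound 2 (0.72 log units; beyond the scatter) and an at least 5.5-fold lower number from compound 1 to compound 3 (0.74 log units; beyond the scatter). They give only a lower bound on size and involve a group that compound 4 does not carry. The closer guide is a 1.1-fold lower number from compound 2 to compound 3 (0.02 log units; within the scatter), an exchange between two phenyl groups bearing chlorine or fluorine, although this rests on compound 2 and compound 3 alone. On that basis, no shift beyond the scatter is expected in this assay, and the expected change is a 1.1-fold higher number from compound 3 to compound 4 (0.05 log units; within the scatter). For compound 4 the estimated value is 20000 nM, with an expected range from 8000 nM to 60000 nM.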

Compound 4, half-maximal inhibitory concentration: 15000 nM
Compound 4: the middle estimate sits 1.3-fold (0.12 log units) above what was measured, within the range that was stated.
By their numbers in this assay, from the lowest: compounds 4, 3 and 2 (each within the scatter of the next). At a limit, above all of these: compound 1.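

In this assay, replacing 3-fluorophenyl with 4-chlorophenyl on the oxygen leaves the value unchanged within the scatter, a 1.2-fold lower number from compound 3 to compound 4 (0.08 log units; within the scatter), and the comparison with the heavily chlorinated group gives the same picture, a 1.3-fold lower number from compound 2 to compound 4 (0.10 log units; within the scatter). Compound 2, compound 3 and compound 4 therefore stand level, so a third phenyl group bearing halogen now supports what had rested on one pair alone. Only compound 1, with 2-methylphenyl, stands apart, and an at least 6.6-fold lower number from compound 1 to compound 4 (0.82 log units; beyond the scatter) gives a bound on size and not a size, since compound 1 is a limit: the limit of > 100000 nM in this assay, at which 1 of the 4 values shown sits.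

The compounds shown leave open whether an unsubstituted phenyl, a 4-methoxyphenyl or a pyridine ring on this oxygen would stay level with these three. They also leave open whether a methyl group elsewhere on the phenyl ring would weaken the number as compound 1 does.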